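Extending the Nitrile of Compound 2: a Cytotoxicity Expectation

This account rests on a few compounds, and the source may have more. Where it says the series, first, only, none or still open, it means among the compounds named here.

Compound 1, `Cc1cc(/C=C/C#N)cc(C)c1Oc1ccnc(Nc2ccc(CN3CCN(S(=O)(=O)N(C)C)CC3)cc2)n1`: 3070 nM
Compound 2, `C=CC(=O)N1CCN(Cc2ccc(Nc3nccc(Oc4c(C)cc(C#N)cc4C)n3)cc2)CC1`: 7580 nM

Of the compounds shown here, two have so far been measured in an ADME assay on MT4 cells (Homo sapiens) for cytotoxicity, read by MTT assay; a lower number here means that less compound is tolerated, a higher number that more compound is tolerated. Compound 2 gives the highest of the two numbers; its nearest neighbour is compound 1, whose number is lower, a gap beyond the usual scatter. Within the data shown here, no single-point step connects these two compounds, as they differ in more than one place, so only their two values can be set side by side.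

Compound 3, `C=CC(=O)N1CCN(Cc2ccc(Nc3nccc(Oc4c(C)cc(/C=C/C#N)cc4C)n3)cc2)CC1`, has not yet been measured in this assay. It differs from compound 2 in one place: 2-cyanoethenyl in place of cyano on an aromatic carbon. In words, 2-cyanoethenyl in place of cyano on an aromatic carbon, meta to two methyl groups and para to a large group.

Compound 1 carries the same 2-cyanoethenyl group but a different tail, so the value of compound 1, 3070 nM, cannot be read as the effect of this change alone. The step of a 1.5-fold lower number from compound 2 to compound 3 (0.18 log units; within the scatter) is expected to be small, toward a lower number, and possibly within the scatter. Compound 3 is therefore estimated at 5000 nM, between 2000 nM and 12000 nM.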

Compound 3, half-maximal cytotoxic concentration: 5210 nM
Estimate against measurement, compound 3: 1.0-fold (0.02 log units) below; the range from low to high includes it.
By their numbers in this assay, from the lowest: compounds 1, 3 and 2 (each within the scatter of the next, the first and the last beyond it).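

Holding the vinylcarbonyl tail fixed, 2-cyanoethenyl in place of cyano on an aromatic carbon, meta to two methyl groups and para to a large group, gives in this assay the first reading of this position alone: a 1.5-fold lower number from compound 2 to compound 3 (0.16 log units; within the scatter) for this extension of the nitrile. Holding 2-cyanoethenyl fixed instead, vinylcarbonyl in place of dimethylsulfamoyl on an amine nitrogen in a ring gives a 1.7-fold higher number from compound 1 to compound 3 (0.23 log units; within the scatter) at the far end of the molecule, so the tail can now be read on its own as well. Each of the two changes, taken alone, stays within the scatter, and nothing at hand accounts for either step.

Whether the cyano-to-2-cyanoethenyl step would stay this small on the dimethylsulfamoyl tail remains open, since the cyano compound with that tail is not among those shown. Also open, on these data alone, is how this aromatic carbon would read with a saturated 2-cyanoethyl chain, a longer chain ending in a nitrile, or a carboxylic acid in place of the nitrile.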